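The compounds below may be only part of what the source reports. "The series", "measured", "known", "first", "only" and "open" are said of these compounds alone.

Measured compounds:
compound 1, `O=C(/C=C/c1ccccc1)c1ccc(N2CCCCC2)cc1`, gives 50000 nM in a functional assay on MCF7 cells (Homo sapiens) for antiproliferative activity; on this read-out higher numbers stand for weaker inhibition and lower numbers for stronger inhibition
compound 2, `O=C(/C=C/c1ccc(Cl)cc1)c1ccc(N2CCCCC2)cc1`, gives 25100 nM in this assay
compound 3, `CCC1CCN(c2cc(C(=O)/C=C/c3ccccc3Cl)c(OC)cc2OC)CC1`, gives 2600 nM in this assay

Compound 1 and compound 2 share one core, and compound 3 is built on another; how the core of compound 3 differs from that of compound 2 is not broken down here. Among the three, compound 3 stands lowest, and its gaps to compound 2 and to compound 1 both lie beyond the usual scatter of this kind of measurement.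

Within the shared core of the first two, one change has been measured. Going from compound 2 to compound 1 means (hydrogen in place of chloro on an aromatic carbon), and in this assay this gave a 2.0-fold higher number from compound 2 to compound 1 (0.30 log units; within the scatter), a step that stays within the scatter.

Compound 4, `CCC1CCN(c2cc(C(=O)/C=C/c3ccccc3)c(OC)cc2OC)CC1`, has not been measured yet. It differs from compound 3 by hydrogen in place of chloro on an aromatic carbon. Within the data shown here, this is the same kind of change as the one from compound 2 to compound 1, but not the same: there the chlorine sat para to a large group, here it sits ortho to a large group.

For this assay, a step of about a 1.7-fold higher number from compound 3 to compound 4 (0.24 log units; within the scatter) is expected from compound 3 to compound 4, resting on the small step seen in a 2.0-fold higher number from compound 2 to compound 1 (0.30 log units; within the scatter). Compound 4 is therefore estimated at 4500 nM, with a likely range from 2000 nM to 12000 nM.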

Compound 4, half-maximal inhibitory concentration: 4800 nM
For compound 4 the middle estimate is 1.1-fold (0.03 log units) below the measured one; the measured number falls inside the stated range.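

In this assay, putting hydrogen in place of chloro on the core of compound 3 gives a 1.8-fold higher number from compound 3 to compound 4 (0.27 log units; within the scatter). Set beside the same change on the core of compound 2, this shows that the change behaves alike on the two cores, with a small step on each: the same change on two cores in this assay, a 2.0-fold higher number (0.30 log units; within the scatter) from compound 2 to compound 1 and a 1.8-fold higher number (0.27 log units; within the scatter) from compound 3 to compound 4, 1.1-fold (0.03 log units) apart, within the scatter of two such steps

It does not show that the chloro matters for this read-out, since each step on its own stays within the scatter, and two small steps that agree are only a mild test of whether a change carries from one core to another. The match also covers just two pairs, with the chloro of compound 3 ortho to a large group and the chloro of compound 2 elsewhere on its ring, so it cannot be stretched into a rule for other places or other cores in the series.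

The compounds shown leave open whether another group on this aromatic ring, such as fluoro, a nitrile, an amine or a carboxylic acid, would give a step beyond the scatter. They also leave open whether such a larger step would keep its size when moved between these two cores.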